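Methyl for methoxy on the fused ring of compound 2

The compounds below may be only part of what the source reports. "The series", "measured", "known", "first", "only" and "open" are said of these compounds alone.

Measured compounds:
Compound 1, `CCOC(=O)c1sc2cccc(C)c2c1Nc1cc(OC)c(OC)c(OC)c1`: 3610 nM
Compound 2, `COC(=O)c1sc2cc(OC)ccc2c1Nc1cc(OC)c(OC)c(OC)c1`: 0.9 nM
Compound 3, `CCOC(=O)c1sc2c(OC)c(C)c(C)c(C)c2c1Nc1cc(OC)c(OC)c(OC)c1`: 14.9 nM

In a functional assay on HT-29 cells (Homo sapiens) for cytotoxicity, read by MTT assay, with a stated time of 72 h (on this read-out lower numbers stand for stronger inhibition and higher numbers for weaker inhibition), compound 2 gives the lowest of the three numbers, the strongest inhibition shown here. Compound 3 stands nearest, and its step to compound 2 lies beyond the usual scatter; compound 1 stands furthest, also beyond the scatter. None of these pairs differs in only one place, so the numbers show only where each compound stands.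

Compound 4, `COC(=O)c1sc2cc(C)ccc2c1Nc1cc(OC)c(OC)c(OC)c1`, is not yet measured. It differs from compound 2 in one place: methyl in place of methoxy on an aromatic carbon. The group on the fused ring system of two rings loses one oxygen, and the compound keeps the rest of compound 2 unchanged.

Among the compounds with values here, no measured pair shows this exact change. Compound 3 carries methyls on its fused ring and still gives 14.9 nM, while compound 1, with a methyl but no methoxy on that ring, gives 3610 nM. A moderate weakening is expected in this assay, a step of a 4.4-fold higher number from compound 2 to compound 4 (0.65 log units; beyond the scatter). Compound 4 is therefore expected to give about 4 nM, within a range from 0.8 nM to 25 nM.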

Compound 4, half-maximal inhibitory concentration: 1.9 nM
Beside the measured number, compound 4's estimate is 2.1-fold (0.32 log units) above it; measured number inside the range.
By their numbers in this assay, from the lowest: compound 2; then compound 4; then compound 3; then compound 1.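

In this assay, placing methyl instead of methoxy on this aromatic carbon gives a 2.1-fold higher number from compound 2 to compound 4 (0.32 log units; beyond the scatter) and so makes a real but modest difference. The methoxy oxygen, with the hydrogen-bond acceptor it counts for, is therefore not required for strong inhibition on this read-out, as compound 4 still gives 1.9 nM in this cell test. The numbers record the size of this step, but nothing measured here explains it.

As far as these compounds go, only methoxy and methyl have been compared at this position, so it remains open how an amine, a chlorine atom or a longer chain such as propoxy would fare there. Also open, from the compounds shown here alone, is whether the same swap would give a similar step at another carbon of the fused ring system.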